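A few compounds are considered here, and "the series" means these few. Any claim that something is new, unique, unknown or untested is made for them only; others in the source may bear on it.

Working notes on the series. Among the measured compounds shown here, in a functional assay on HeLa cells (Homo sapiens) for inhibition, read by CCK-8 assay, with a stated time of 72 h, tested at 10 uM (a higher number here means more inhibition of growth at the concentration tested, a lower number less inhibition of growth), compound 1 (`CN(C)C(=O)c1cc2cnc(Nc3ccc(NC(=O)C4(C(=O)Nc5ccc(F)cc5)CC4)cc3)nc2n1C1CCCC1`) gives 73.7% and compound 2 (`CN(C)C(=O)c1cc2cnc(Nc3ccc(NC(=O)C4(C(=O)Nc5ccc(Cl)c(C(F)(F)F)c5)CC4)cc3)nc2n1C1CCCC1`) gives 55.6%, so compound 2 holds the lower of the two numbers so far. Compound 3 (`CN(C)C(=O)c1cc2cnc(Nc3ccc(NC(=O)C4(C(=O)Nc5ccc(O)cc5)CC4)cc3)nc2n1C1CCCC1`) keeps the rest of compound 2 and changes one group: 4-hydroxyphenyl in place of 4-chloro-3-(trifluoromethyl)phenyl on an amide-type nitrogen. In words, 4-hydroxyphenyl stands in place of 4-chloro-3-(trifluoromethyl)phenyl on an amide-type nitrogen.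

For the measured compounds named here, one measured step bears on this change, at the same place and involving the same departing group: a number 18.1 percentage points lower from compound 1 to compound 2 (beyond the scatter). Read in reverse, it shows that compound 1, without 4-chloro-3-(trifluoromethyl)phenyl, stands higher at 73.7%. Going by the values given here, no measured compound carries 4-hydroxyphenyl, so that single step is only a loose guide, and how this group compares with 4-fluorophenyl is unknown. A rise in this assay is therefore expected, somewhat smaller than the measured step. The expected change is a number 11.4 percentage points higher from compound 2 to compound 3 (beyond the scatter). For compound 3 the estimated value is 67%, with an expected range from 50% to 82%.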

Compound 3, percent growth inhibition at one concentration: 99.9%
The estimate for compound 3 lay 32.9 percentage points below the measured number; measured number outside the range, above it.
By their numbers in this assay, from the lowest: compound 2; then compound 1; then compound 3.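

In this assay, the result shows that this position responds strongly to the aryl group on the amide-type nitrogen: 4-hydroxyphenyl in place of 4-chloro-3-(trifluoromethyl)phenyl gives a number 44.3 percentage points higher from compound 2 to compound 3 (beyond the scatter), and the exchange of a single group, hydroxy in place of fluoro on an aromatic carbon, gives a number 26.2 percentage points higher from compound 1 to compound 3 (beyond the scatter). The earlier pair showed only a fall on going to 4-chloro-3-(trifluoromethyl)phenyl, whereas compound 3 now places 4-hydroxyphenyl above both halogen-bearing compounds, so the change is more than the departure of 4-chloro-3-(trifluoromethyl)phenyl. Nothing available accounts for this rise or links it to the hydrogen-bond donor and acceptor that the hydroxy group brings.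

The compounds shown leave open whether the rise is specific to the hydroxy group, as they include no 4-methoxyphenyl, 4-aminophenyl or 4-carboxyphenyl group at this place on the amide-type nitrogen. With compound 3 at 99.9% at a single concentration, any difference between it and a still stronger analogue would also need a read-out across several concentrations.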